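Fluoro for hydrogen on the aniline ring, oral exposure

This account rests on a few compounds, and the source may have more. Where it says the series, first, only, none or still open, it means among the compounds named here.

Measured so far:
compound 1, `Cc1ccc(-n2nc(C(C)(C)C)cc2NC(=O)Nc2cccc(Oc3ccnc4[nH]c(=O)cnc34)c2)cc1`, 27%
compound 2, `Cc1ccc(-n2nc(C(C)(C)C)cc2NC(=O)Nc2ccc(Oc3ccnc4[nH]c(=O)cnc34)cc2)cc1`, 17%

Two compounds carry numbers in an in vivo ADME assay on the whole organism (strain C57BL/cAnNCrl) for pharmacokinetics, with Mus musculus as the target, at a dose of 10 mg/kg by the oral route; on this read-out lower numbers stand for lower oral bioavailability and higher numbers for higher oral bioavailability. Compound 1 gives 27% in this assay, and compound 2 gives 17%. The gap between the two lies within the scatter of this assay, so the two numbers do not separate and no ordering can be drawn from them; compound 2 simply sits beside compound 1 on the scale.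

Compound 3, `Cc1ccc(-n2nc(C(C)(C)C)cc2NC(=O)Nc2ccc(Oc3ccnc4[nH]c(=O)cnc34)cc2F)cc1`, has not yet been measured in this assay. It differs from compound 2 in one place: fluoro in place of hydrogen on an aromatic carbon. Among the measured compounds shown here, no step between measured compounds of this kind is available, so nothing here tells how such a change moves the read-out.

For the measured compounds named here, with no guiding step, the expectation for compound 3 is a number close to that of compound 2, and the step from compound 2 to compound 3 is expected to be a number 3 percentage points higher from compound 2 to compound 3 (within the scatter), that is, none beyond the scatter. Compound 3 is therefore estimated at 20% in this assay, with a range from 8% to 38%.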

Compound 3, oral bioavailability: 24%
Beside the measured number, compound 3's estimate is 4 percentage points below it; the range from low to high includes it.
By their numbers in this assay, from the lowest: compounds 2, 3 and 1 (each within the scatter of the next).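

In this assay, the series now has its first step for fluoro in place of hydrogen on an aromatic carbon, here on the six-membered aromatic ring of carbon only, ortho to a large group and meta to a large group: a number 7 percentage points higher from compound 2 to compound 3 (within the scatter). At this one position, on the background of compound 2, the exchange therefore leaves the two numbers unseparated, so this single step gives no sign that fluoro here shifts oral bioavailability beyond the usual scatter of the measurement. Nothing measured at hand bears on the reason for this result, and the step alone offers no explanation for it.

Still open, from the compounds shown here alone, is whether fluoro on another carbon of the same ring, or on the corresponding ring of compound 1, would give a step of similar size. Also open, going by these compounds, is whether a chlorine, a methoxy group or an amine on the same carbon would stay within the scatter or move the number beyond it, since one step of one kind cannot settle how this position responds to other groups.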